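The source may hold more compounds than are shown below. What is called first, only, known or untested is meant among the compounds shown, and "the series" means these compounds.

Measured compounds in a functional assay on MOLT-4 cells (Homo sapiens) for inhibition, read by sulforhodamine B assay, with a stated time of 48 h; on this read-out higher numbers stand for weaker inhibition of growth and lower numbers for stronger inhibition of growth:

Compound 1 `COc1cc(-c2nn(-c3cccc(NC(=O)c4ccc(Cl)c(C(F)(F)F)c4)c3)cc2-c2ccncc2)ccc1Cl`. In this assay compound 1 gives > 32500 nM; this is a limit of the assay, not a number.
Compound 2 `O=C(Nc1cccc(-n2cc(-c3ccncc3)c(-c3ccc(Cl)c(O)c3)n2)c1)Nc1cc(C(F)(F)F)cc(C(F)(F)F)c1`. In this assay compound 2 gives 4360 nM.
Compound 3 `COc1cc(-c2nn(-c3cccc(NC(=O)Nc4ccc(Cl)c(C(F)(F)F)c4)c3)cc2-c2ccncc2)ccc1Cl`. In this assay compound 3 gives 7960 nM.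

Compound 2 has the lowest of the two numbers shown; its nearest neighbour is compound 3, and the gap between them is within the scatter, so no order can be read between the two. Among the compounds with values here, the one measured step is an at least 4.0-fold lower number from compound 1 to compound 3 (0.61 log units; beyond the scatter), which rests on the limit (the limit of > 32500 nM in this assay, at which 1 of the 3 values shown sits).

Compound 4 `O=C(Nc1cccc(-n2cc(-c3ccncc3)c(-c3ccc(Cl)c(O)c3)n2)c1)Nc1cccc(C(F)(F)F)c1` is not yet measured. It differs from compound 2 by hydrogen in place of trifluoromethyl on an aromatic carbon. No measured step in the series touches this part of the molecule, so nothing shown bears directly on the change; the only measured step concerns the linker between the two aryl groups. With no guidance, the change from compound 2 to compound 4 is expected to lie within the scatter, a 1.4-fold higher number from compound 2 to compound 4 (0.14 log units; within the scatter), at most a slight weakening. For compound 4 the expected value in this assay is 6000 nM, estimated to fall between 2500 nM and 15000 nM.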

Compound 4, concentration for total growth inhibition: > 32500 nM
Compound 4: no number, only a limit; the forecaster's own chance of this, stated with the estimate: 5%; middle value at least 5.4-fold (0.73 log units) away from the limit.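

Hydrogen in place of trifluoromethyl gives an at least 7.4-fold higher number from compound 2 to compound 4 (0.87 log units; beyond the scatter) in this assay, so this position, which the earlier step on the linker did not touch, clearly matters for the read-out. Compound 4 gives > 32500 nM; this is a limit of the assay, not a number, so the step gives only a lower bound on the size of the change. The series now has more values at this limit, and neither can be ranked against the other: the limit of > 32500 nM in this assay, at which 2 of the 4 values shown sit.

With only trifluoromethyl and hydrogen shown at this position, how a chlorine, a methyl or a nitrile there would read remains open. Also open, from the compounds shown here alone, is whether the same replacement would have a similar effect on compound 3, which differs from compound 2 in more than one place.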